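Aryl substituent series: chloro to cyano

A few compounds are considered here, and "the series" means these few. Any claim that something is new, unique, unknown or untested is made for them only; others in the source may bear on it.

The series shares one core, seen in compound 1 `O=C1/C(=C/c2ccccc2)Cc2cc(O)ccc21`, compound 2 `O=C1/C(=C/c2ccc(F)cc2)Cc2cc(O)ccc21` and compound 3 `O=C1/C(=C/c2cccc(Cl)c2)Cc2cc(O)ccc21`. In an assay on isolated protein for inhibition of Amine oxidase [flavin-containing] B (Homo sapiens), read by fluorescence and spectrophotometry, with a stated time of 20 min (a lower number here means a stronger inhibitor, a higher number a weaker inhibitor), compound 1 gives 376 nM, compound 2 gives 47 nM and compound 3 gives 30 nM. Compound 3 has the lowest number of the three; its gap to compound 2 lies within the scatter, so those two cannot be ordered, while its gap to compound 1 lies beyond it. The two measured steps are an 8.0-fold lower number from compound 1 to compound 2 (0.90 log units; beyond the scatter) and a 13-fold lower number from compound 1 to compound 3 (1.10 log units; beyond the scatter), each placing a halogen where the parent has hydrogen. Compound 4 `N#Cc1cccc(/C=C2\Cc3cc(O)ccc3C2=O)c1` differs from compound 3 by cyano in place of chloro on an aromatic carbon. Among the measured compounds shown here, no measured step swaps one substituent for another, so the measured steps bear only indirectly: they show that a group entering on an aromatic carbon can move the number well beyond the scatter, in both cases downward. Compound 4 is thus expected to sit close, the estimated step being a 2.0-fold higher number from compound 3 to compound 4 (0.30 log units; within the scatter). The estimate for compound 4 in this assay is 60 nM, expected between 15 nM and 250 nM.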

Compound 4, half-maximal inhibitory concentration: 130 nM
Estimate against measurement, compound 4: 2.2-fold (0.34 log units) below; measured number inside the range.
By their numbers in this assay, from the lowest: compounds 3 and 2 (each within the scatter of the next); then compound 4; then compound 1.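

Swapping one substituent for another at this place gives a 4.3-fold higher number from compound 3 to compound 4 (0.64 log units; beyond the scatter) in this assay, so chloro and cyano on this aromatic carbon are not interchangeable, a point the steps from hydrogen alone could not show. Cyano still keeps a gain over the parent, with a 2.9-fold lower number from compound 1 to compound 4 (0.46 log units; beyond the scatter) as its step, so all three substituents shown move the number downward from hydrogen, and none goes against this.

Open, as far as these compounds go, is how a methoxy group, an amine or a carboxylic acid at this place would compare with chloro and cyano, and whether the gap between chloro and cyano would hold on other aromatic carbons of the same ring. Nothing at hand bears on what lies behind the difference between chloro and cyano.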